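The source may hold more compounds than are shown below. What is called first, only, known or untested is meant among the compounds shown, and "the series" means these compounds.

Going by the values given here, in a functional assay on MCF7 cells (Homo sapiens) for antiproliferative activity, read by sulforhodamine B assay, with a stated time of 72 h (a higher number here means a weaker inhibitor, a lower number a stronger inhibitor), compound 2 `FC(F)(F)c1ccc(/C=C\c2cc3ccc(Cl)cc3nc2Cl)cc1` gives 6450 nM, the lower of the two numbers so far, while compound 1 `Fc1ccc(/C=C\c2cc3ccccc3nc2Cl)cc1` gives 20300 nM. These two compounds differ in more than one place, so their gap cannot be tied to any single change. Compound 3 `Fc1ccc(/C=C\c2cc3ccc(Cl)cc3nc2Cl)cc1` departs from compound 2 in one place, with fluoro in place of trifluoromethyl on an aromatic carbon. Compound 1, which also carries fluoro, gives 20300 nM, so a modest weakening is expected in this assay. The expected step, slightly beyond the scatter, is a 1.5-fold higher number from compound 2 to compound 3 (0.17 log units; within the scatter). The estimated value for compound 3 is 9500 nM, within an expected range of 4000 nM to 22000 nM.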

Compound 3, half-maximal inhibitory concentration: 16900 nM
Compound 3: middle estimate off by 1.8-fold (0.25 log units), on the low side; measured number inside the range.
By their numbers in this assay, from the lowest: compound 2; then compounds 3 and 1 (each within the scatter of the next).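

In this assay, the group on this aromatic carbon, para to a large group, clearly matters: fluoro in place of trifluoromethyl gives a 2.6-fold higher number from compound 2 to compound 3 (0.42 log units; beyond the scatter). Chloro in place of hydrogen on an aromatic carbon, with fluoro kept, gives a 1.2-fold lower number from compound 1 to compound 3 (0.08 log units; within the scatter), so this second change shows no clear effect on the number. Nothing measured here explains the difference between fluoro and trifluoromethyl. Still open, as far as these compounds go, is how an amine, a carboxylic acid or a longer chain at the same position would compare with trifluoromethyl.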